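The source may report more compounds than this note shows. Statements on the series, on what has been measured and on what is new or still open speak of the compounds shown alone.

Measured so far in a functional assay on NCI-H1993 cells (Homo sapiens) for inhibition, read by CCK-8 assay, with a stated time of 72 h; a lower number here means a stronger inhibitor, a higher number a weaker inhibitor:
- compound 1 `Nc1ccc(-c2cnc3ncn(Cc4ccc5ncccc5c4)c3n2)cc1`: 4950 nM
- compound 2 `c1cnc2ccc(Cn3cnc4ncc(-c5ccncc5)nc43)cc2c1`: 1160 nM

Compound 2 stands lowest of these two numbers. Among the compounds with values here, the single measured step is a 4.3-fold lower number from compound 1 to compound 2 (0.63 log units; beyond the scatter), with pyridin-4-yl in place of 4-aminophenyl on an aromatic carbon, and it lies beyond the scatter.

The next compound is compound 3 `c1ccc(-c2cnc3ncn(Cc4ccc5ncccc5c4)c3n2)cc1`. Its difference from compound 2 is phenyl in place of pyridin-4-yl on an aromatic carbon. Within the data shown here, this is the same place that changed in the measured step, which is therefore the only guide. Among the measured compounds shown here, that guide is partial, since compound 1 carries an amino group that compound 3 lacks, and no measured compound carries plain phenyl.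

For the measured compounds named here, a move to a higher number in this assay is expected, resting on compound 1 at 4950 nM, the one measured compound with a ring of carbon only at this place. The size is expected to be close to that of the measured step, though smaller, and the step is estimated as a 2.6-fold higher number from compound 2 to compound 3 (0.41 log units; beyond the scatter). For compound 3 the estimated value is 3000 nM, with an expected range of 1100 nM to 8000 nM.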

Compound 3, half-maximal inhibitory concentration: 7490 nM
The estimate for compound 3 lay 2.5-fold (0.40 log units) below the measured number; the range from low to high includes it.
By their numbers in this assay, from the lowest: compound 2; then compounds 1 and 3 (each within the scatter of the next).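

In this assay, pyridin-4-yl gives way to phenyl at this aromatic carbon with the same count of heavy atoms and the same ring size, so the ring nitrogen and its one hydrogen-bond acceptor are the only things lost, and the result is a 6.5-fold higher number from compound 2 to compound 3 (0.81 log units; beyond the scatter). Removing the amino group from the carbon-only ring gives a 1.5-fold higher number from compound 1 to compound 3 (0.18 log units; within the scatter), so compound 1 and compound 3 cannot be told apart, and the amino group adds nothing readable here; among these three compounds, the one with a ring nitrogen at this place is the one that stands apart, and none goes against this. No evidence beyond these numbers bears on the result, so the step stays an observation without an explanation.

The compounds shown leave open whether the ring nitrogen must sit where pyridin-4-yl places it, a question that pyridin-3-yl, pyridin-2-yl or pyrimidin-5-yl at the same carbon would address. Also open, from the compounds shown here alone, is whether a second substituent, such as an amine or a methoxy group on the pyridin-4-yl ring itself, would move the number further from that of compound 2.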